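Urea Restored on the Shared Core: Compound 3 to Compound 4

The compounds below may be only part of what the source reports. "The series", "measured", "known", "first", "only" and "open" are said of these compounds alone.

Measured compounds:
Compound 1 `O=C(Nc1cccc(-n2cc(-c3ccncc3)c(-c3ccc(Cl)c(O)c3)n2)c1)Nc1cccc(C(F)(F)F)c1`: > 32500 nM
Compound 2 `COc1cc(-c2nn(-c3cccc(NC(=O)Nc4cc(C(F)(F)F)cc(C(F)(F)F)c4)c3)cc2-c2ccncc2)ccc1Cl`: 2950 nM
Compound 3 `COc1cc(-c2nn(-c3cccc(NC(=O)c4cccc(C(F)(F)F)c4)c3)cc2-c2ccncc2)ccc1Cl`: > 50000 nM

The three measured compounds were tested in a functional assay on HOP-62 cells (Homo sapiens) for inhibition, read by sulforhodamine B assay, with a stated time of 48 h; on this read-out lower numbers stand for higher toxicity in this test and higher numbers for lower toxicity in this test. Compound 3 `COc1cc(-c2nn(-c3cccc(NC(=O)c4cccc(C(F)(F)F)c4)c3)cc2-c2ccncc2)ccc1Cl` stands at a limit of the assay, > 50000 nM, so no number is known for it; the evidence note the limit of > 50000 nM in this assay, at which 1 of the 3 values shown sits, records this. Compound 1 likewise gives only a limit, > 32500 nM, as noted in the limit of > 32500 nM in this assay, at which 1 of the 3 values shown sits. Among the measured compounds shown here, compound 2 alone gives a number, 2950 nM, and it is the only compound of the three that carries a urea linker.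

Compound 4 `COc1cc(-c2nn(-c3cccc(NC(=O)Nc4ccc(Cl)c(Cl)c4)c3)cc2-c2ccncc2)ccc1Cl` has not yet been measured. Compared with compound 3 the change is (3,4-dichlorophenyl)amino in place of 3-(trifluoromethyl)phenyl on a carbonyl carbon, which turns the amide of compound 3 back into a urea of the kind seen in compound 2. For the measured compounds named here, no measured step joins these two compounds, so the size of the change can only be expected.

Given that compound 2 gives 2950 nM with a urea, compound 4 is expected to give a measurable number, with an expected step of an at least 10-fold lower number from compound 3 to compound 4 (1.00 log units; beyond the scatter) toward higher toxicity in this test. Compound 4 is estimated at 5000 nM, within a range from 1500 nM to 25000 nM.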

Compound 4, concentration lethal to 50% of the cells: > 50000 nM
Compound 4 ended at the assay's limit; the forecaster's own chance of this, stated with the estimate: 25%; middle value at least 10-fold (1.00 log units) from the limit.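

In this assay compound 4 gives > 50000 nM as a limit of the assay and not a number. Among the compounds shown here, compound 3 sits at the same kind of limit, so no step between the two can be read: the limit of > 50000 nM in this assay, at which 2 of the 4 values shown sit. The compounds shown leave open how far compound 3 and compound 4 actually differ in this test.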